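A few compounds are considered here, and "the series" means these few. Any claim that something is new, unique, unknown or untested is made for them only; others in the source may bear on it.

Compound 3 `CCCCCCCCCCCC(=O)OC[C@H](CSC[C@@H](N)C(=O)NCCCN)OC(=O)CCCCCCCCCCC` gives 1960 nM in an assay on HEK293 cells for agonist activity at Toll-like receptor 2 (Homo sapiens) (a lower number here means that less compound is needed, a higher number that more compound is needed for the effect), and stands lowest of the three numbers in hand. Compound 1 `CCCCCCCCCCCC(=O)OC[C@H](CSC[C@@H](N)C(=O)NCCCS(=O)(=O)O)OC(=O)CCCCCCCCCCC` gives 5560 nM and compound 2 `CCCCCCCCCCCC(=O)OC[C@H](CSC[C@@H](N)C(=O)NC(C)c1ccccc1)OC(=O)CCCCCCCCCCC` gives 9900 nM; the steps of a 2.8-fold lower number from compound 1 to compound 3 (0.45 log units; beyond the scatter) and a 5.1-fold lower number from compound 2 to compound 3 (0.70 log units; beyond the scatter) both lie beyond the scatter, while a 1.8-fold higher number from compound 1 to compound 2 (0.25 log units; within the scatter) does not. Compound 4 `CCCCCCCCCCCC(=O)OC[C@H](CSC[C@@H](N)C(=O)NCCCCN)OC(=O)CCCCCCCCCCC` carries aminomethyl in place of amino on a saturated chain carbon, three bonds along the chain from an amide-type nitrogen; read one bond further out, the change is 3-aminopropyl to 4-aminobutyl. Among the measured compounds shown here, no measured pair differs only in the length of this chain; the two steps reaching compound 3 concern the terminal group and the whole substituent, and the amino terminus is retained in compound 4. A step within the scatter is therefore expected, a 1.0-fold higher number from compound 3 to compound 4 (0.01 log units; within the scatter). Compound 4 is estimated at 2000 nM, with a range from 800 nM to 5000 nM.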

Compound 4, half-maximal effective concentration: 1040 nM
For compound 4 the middle estimate is 1.9-fold (0.28 log units) above the measured one, within the range that was stated.
By their numbers in this assay, from the lowest: compounds 4 and 3 (each within the scatter of the next); then compounds 1 and 2 (each within the scatter of the next).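

Going from 3-aminopropyl to 4-aminobutyl gives a 1.9-fold lower number from compound 3 to compound 4 (0.28 log units; within the scatter) in this assay, so at this position the added chain carbon leaves the number within the scatter. The amino-ended chain of compound 4 also keeps the separation from the other substituents, with a 9.5-fold lower number from compound 2 to compound 4 (0.98 log units; beyond the scatter) and a 5.3-fold lower number from compound 1 to compound 4 (0.73 log units; beyond the scatter) on the same core. No measurement on hand accounts for these steps. Still open, going by these compounds, is whether 2-aminoethyl or a longer amine chain would stay at this level, and how a carboxylic acid at the chain end would compare.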